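The compounds below may be only part of what the source reports. "The series", "measured", "known", "first", "only" and "open" are said of these compounds alone.

Measured so far:
- compound 1, `CCCCCc1ccc(NS(=O)(=O)c2ccc(N3CCNC3=O)cc2)cc1` — 870 nM
- compound 2, `O=C1NCCN1c1ccc(S(=O)(=O)Nc2cccc(Br)c2)cc1` — 59 nM
- compound 3, `CCCCOc1ccc(NS(=O)(=O)c2ccc(N3CCNC3=O)cc2)cc1` — 580 nM

In a functional assay on M21 cells (Homo sapiens) for antiproliferative activity, read by sulforhodamine B assay, with a stated time of 48 h (on this read-out higher numbers stand for weaker inhibition and lower numbers for stronger inhibition), compound 1 gives the highest of the three numbers. Its nearest neighbour is compound 3, reached by a 1.5-fold lower number from compound 1 to compound 3 (0.18 log units; within the scatter); its furthest is compound 2, whose value of 59 nM is well beyond the scatter from that of compound 1.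

Compound 4, `O=C1NCCN1c1ccc(S(=O)(=O)Nc2ccc(I)cc2)cc1`, is the next compound in this assay. It differs from compound 1 in one place: iodo in place of pentyl on an aromatic carbon. Among the measured compounds shown here, the only measured step at this position is the one from compound 1 to compound 3, where butoxy in place of pentyl left the number essentially where it was. That step offers little guidance for a single halogen atom. For the measured compounds named here, compound 2, the only halogenated compound measured, carries bromo and gives a far lower number than compound 1, though no single-change step connects the two. Weighing these, the account expects compound 4 to show a 7.9-fold lower number from compound 1 to compound 4 (0.90 log units; beyond the scatter). The estimate for compound 4 in this assay is 110 nM, with a range from 35 nM to 400 nM.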

Compound 4, half-maximal inhibitory concentration: 260 nM
For compound 4 the middle estimate is 2.4-fold (0.37 log units) below the measured one; the measured number falls inside the stated range.
By their numbers in this assay, from the lowest: compound 2; then compound 4; then compounds 3 and 1 (each within the scatter of the next).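

In this assay a single iodo atom on this aromatic carbon moves the number beyond the scatter, which butoxy in place of pentyl did not do: the change gives a 3.3-fold lower number from compound 1 to compound 4 (0.52 log units; beyond the scatter) and also a 2.2-fold lower number from compound 3 to compound 4 (0.35 log units; beyond the scatter) when iodo replaces butoxy. Carrying a halogen does not by itself match compound 2, since 4-iodophenyl in place of 3-bromophenyl on the sulfonamide nitrogen gives a 4.4-fold higher number from compound 2 to compound 4 (0.64 log units; beyond the scatter) in the same assay. Nothing available here accounts for these steps.

That last change alters both the halogen and where it sits, so the compounds shown leave open which of the two carries the gap to compound 2. They also leave open how a chloro, a fluoro or an amine would compare with iodo on this aromatic carbon.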